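The source may report more compounds than this note shows. Statements on the series, on what has been measured and on what is new or still open speak of the compounds shown alone.

Measured so far in an assay on isolated protein for activation of Nicotinamide phosphoribosyltransferase (Homo sapiens); a higher number here means that more compound is needed for the effect, a lower number that less compound is needed:
compound 1 `CCOC(=O)c1ccc(NC(=O)NCc2cocn2)cc1` gives 27600 nM;
compound 2 `CCOC(=O)c1ccc(NC(=S)NCc2ccncc2)cc1` gives 9770 nM;
compound 3 `CN(Cc1ccccc1)S(=O)(=O)c1ccc(NC(=O)NCc2ccncc2)cc1` gives 23 nM.

Compound 3 has the lowest number of the three in this assay. Compound 2 stands nearest to it and compound 1 furthest, and both gaps lie beyond the scatter. No two of these compounds differ in one place only, so no single measured step is available to lean on.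

Compound 4 `O=C(NCc1ccncc1)Nc1ccc(S(=O)(=O)NCc2ccccc2)cc1` differs from compound 3 in one place: hydrogen in place of methyl on a sulfonamide nitrogen. Among the compounds with values here, nothing among the measured compounds shows what such a change does here. A small step is expected, if any, slightly toward a higher number, and likely within the scatter. Compound 4 is expected at 40 nM, with a range of 10 nM to 160 nM. The step of a 1.7-fold higher number from compound 3 to compound 4 (0.24 log units; within the scatter) is the expected outcome.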

Compound 4, half-maximal effective concentration: 102 nM
For compound 4 the middle estimate is 2.6-fold (0.41 log units) below the measured one; the range from low to high includes it.
By their numbers in this assay, from the lowest: compound 3; then compound 4; then compound 2; then compound 1.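

In this assay, within the data shown here, replacing methyl with hydrogen on the sulfonamide nitrogen gives a 4.4-fold higher number from compound 3 to compound 4 (0.65 log units; beyond the scatter), a modest step and the first single-place comparison. The number therefore responds to this one substituent, and benzyl(methyl)amino gives the lower value of the pair. No available evidence accounts for the step.

With only hydrogen and methyl shown at this nitrogen, the trend with size remains undefined. As far as these compounds go, whether an ethyl group or a longer chain would lower the number further, or raise it, stays open.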